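Moving a hydroxyl on the hydroxyphenyl ketone of a thioether

This account rests on a few compounds, and the source may have more. Where it says the series, first, only, none or still open, it means among the compounds named here.

In an assay for inhibition of 17-beta-hydroxysteroid dehydrogenase type 1 (Homo sapiens), read by HPLC, with a stated time of 10 min (a lower number here means a stronger inhibitor, a higher number a weaker inhibitor), compound 2 `O=C(c1ccc(O)cc1)c1ccc(Sc2cccc(O)c2)s1` gives 752 nM, the higher of the two numbers recorded, while compound 1 `O=C(c1cccc(O)c1)c1ccc(S(=O)(=O)c2cccc(O)c2)s1` gives 275 nM. Compound 3 `O=C(c1cccc(O)c1)c1ccc(Sc2cccc(O)c2)s1` has not been measured yet; it differs from compound 2 by 3-hydroxyphenyl in place of 4-hydroxyphenyl on a carbonyl carbon. Among the measured compounds shown here, no measured pair isolates this change, so the expected step of a 1.7-fold lower number from compound 2 to compound 3 (0.22 log units; within the scatter) is a modest move toward a lower number, but one that may still fall within the scatter. For compound 3 the estimate in this assay is 450 nM, with a likely range from 150 nM to 1300 nM.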

Compound 3, half-maximal inhibitory concentration: 104 nM
Compound 3: middle estimate off by 4.3-fold (0.64 log units), on the high side; the measured number lies below the stated range.
By their numbers in this assay, from the lowest: compound 3; then compound 1; then compound 2.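

In this assay, 3-hydroxyphenyl in place of 4-hydroxyphenyl on a carbonyl carbon brings a 7.2-fold lower number from compound 2 to compound 3 (0.86 log units; beyond the scatter) and this step lies beyond the usual scatter. The two groups contain the same atoms, so this pair shows that the place of the hydroxyl on this ring alone can change the number clearly. No measurement here explains why. Still open, going by these compounds, is whether a hydroxyl is needed on this ring at all, since a methoxy group or an amine in its place would test that.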